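Cytotoxicity Limits and a Side-Chain Swap on the Core

The source may report more compounds than this note shows. Statements on the series, on what has been measured and on what is new or still open speak of the compounds shown alone.

Compound 1 `Cc1ccn2c(CCCCO)c(Cn3c(=O)n(C4CC4)c4ccncc43)nc2c1` gives > 100000 nM in an ADME assay on HEp-2 cells (Homo sapiens) for cytotoxicity, read by CCK-8 assay, with a stated time of 6 days (on this read-out higher numbers stand for lower toxicity in this test and lower numbers for higher toxicity in this test), a limit of the assay.
Compound 2 `O=c1n(Cc2nc3cc(C(F)(F)F)ccn3c2CCCCO)c2cnccc2n1C1CC1` gives > 100000 nM in this assay, also a limit.
Compound 3 `O=C(O)c1c(Cn2c(=O)n(C3CC3)c3ccncc32)nc2cc(Cl)ccn12` gives > 100000 nM in this assay, again a limit.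

Compound 3 therefore stands where every measured compound stands: the limit of > 100000 nM in this assay, at which 3 of the 3 values shown sit. For the measured compounds named here, the only step between measured compounds, a step that the two limits leave unreadable from compound 1 to compound 2, cannot be read in size. Compound 4 `O=c1n(Cc2nc3cc(Cl)ccn3c2CNCCO)c2cnccc2n1C1CC1` differs from compound 3 by ((2-hydroxyethyl)amino)methyl in place of carboxy on an aromatic carbon. Going by the values given here, no measured step bears on this change, so no movement beyond the scatter is expected, and the reading is most likely to be a limit once more. Compound 4 is expected to give 100000 nM, between 30000 nM and 300000 nM. This estimate corresponds to an expected step of a number no higher from compound 3 to compound 4 (the limit leaves the size open).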

Compound 4, half-maximal cytotoxic concentration: > 100000 nM
Compound 4 gave a limit, no number; the forecaster's own chance of this, stated with the estimate: 80%; the middle value sits exactly at the limit.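

For the compounds shown here, compound 3 and compound 4 both give only a limit, so no step between them can be read. The compounds shown leave open which change, if any, would bring a measurable number in this assay: the limit of > 100000 nM in this assay, at which 4 of the 4 values shown sit.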